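The source may report more compounds than this note shows. Statements on the series, on what has been measured and on what is new or still open speak of the compounds shown alone.

Compound 3 `CC(=O)Nc1cccc2c1CCCC2c1c[nH]cn1` is one of three close relatives that carry the same core. In an assay on isolated protein (Cricetulus griseus) for binding affinity to Alpha-1B adrenergic receptor (Mesocricetus auratus), read by radioligand binding (a lower number here means a stronger inhibitor, a higher number a weaker inhibitor), compound 3 gives < 10000 nM, which is a limit of the assay and not a number. The same holds for its neighbours: compound 1 `CC(C)S(=O)(=O)Nc1cccc2c1CCCC2c1c[nH]cn1` gives < 10000 nM in this assay, a limit. Compound 2 `O=S(=O)(Nc1cccc2c1CCCC2c1c[nH]cn1)C1CC1` gives < 10000 nM in this assay, again a limit. Thus the limit of < 10000 nM in this assay, at which 3 of the 3 values shown sit, is all the evidence. The three steps among them, a step that the two limits leave unreadable from compound 1 to compound 2, a step that the two limits leave unreadable from compound 1 to compound 3 and a step that the two limits leave unreadable from compound 2 to compound 3, cannot be read. Compound 4 `COC(=O)Nc1cccc2c1CCCC2c1c[nH]cn1` differs from compound 3 by methoxy in place of methyl on a carbonyl carbon. With no readable step to lean on, the expected step that the limit leaves unreadable from compound 3 to compound 4 is not beyond the scatter. Compound 4 is therefore estimated at 2000 nM, ranging from 200 nM to 10000 nM.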

Compound 4, inhibition constant: 10000 nM
For compound 4 the middle estimate is 5.0-fold (0.70 log units) below the measured one, and the stated range covers the measured number.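

In this assay compound 4 gives 10000 nM, the only actual number among the compounds shown. Compound 1, compound 2 and compound 3 each sit at a limit of the assay: the limit of < 10000 nM in this assay, at which 3 of the 4 values shown sit. The number for compound 4 still gives no size for the change. The three steps are a number no lower from compound 3 to compound 4 (the limit leaves the size open), a number no lower from compound 2 to compound 4 (the limit leaves the size open) and a number no lower from compound 1 to compound 4 (the limit leaves the size open), and the size of none of them can be read. On these data alone, it remains open how an ethoxy or a dimethylamino group on the same carbonyl carbon would read in this assay.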